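This account rests on a few compounds, and the source may have more. Where it says the series, first, only, none or still open, it means among the compounds named here.

In a functional assay on HCT-116 cells (Homo sapiens) for antiproliferative activity, with a stated time of 72 h (a higher number here means a weaker inhibitor, a lower number a stronger inhibitor), compound 1 `O=C(COc1ccc(CNC2CC=C(c3c[nH]c4cccc(F)c34)CC2)c(F)c1)NO` gives 173 nM and compound 2 `O=C(COc1ccc(CNC2CC=C(c3c[nH]c4ccc(F)cc34)CC2)c(F)c1)NO` gives 261 nM as its value, the two lying within the scatter of each other. Compound 3 `Cc1ccc2[nH]cc(C3=CCN(Cc4ccc(OCC(=O)NO)cc4F)CC3)c2c1` gives 1450 nM as a clearly higher number than compound 2 shows. Compound 4 `Cc1ccc2[nH]cc(C3=CCC(NCc4ccc(OCC(=O)NO)cc4F)CC3)c2c1` differs from compound 2 by methyl in place of fluoro on an aromatic carbon in a swap of methyl in place of fluoro on an aromatic carbon. Within the data shown here, the one measured step touching that ring is a 1.5-fold higher number from compound 1 to compound 2 (0.18 log units; within the scatter) and it involves no methyl, so it offers only indirect guidance. No shift beyond the scatter is therefore expected in this assay for this swap. The estimated step is a 1.1-fold higher number from compound 2 to compound 4 (0.06 log units; within the scatter) and so stays within the scatter. For compound 4 the expected value is 300 nM within an estimated range of 130 nM to 700 nM overall.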

Compound 4, half-maximal inhibitory concentration: 445 nM
Compound 4: middle estimate off by 1.5-fold (0.17 log units), on the low side; the measured number falls inside the stated range.
By their numbers in this assay, from the lowest: compounds 1, 2 and 4 (each within the scatter of the next, the first and the last beyond it); then compound 3.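

In this assay, methyl in place of fluoro on this aromatic carbon gives a 1.7-fold higher number from compound 2 to compound 4 (0.23 log units; within the scatter), so the 5-methyl-1H-indol-3-yl and 5-fluoro-1H-indol-3-yl groups cannot be told apart here. Set against the 4-fluoro-1H-indol-3-yl group, the same methyl group gives a 2.6-fold higher number from compound 1 to compound 4 (0.41 log units; beyond the scatter), a modest shift that, unlike the step between the two fluoro compounds, lies beyond the scatter. No evidence is available to explain either step.

Still open, from the compounds shown here alone, is whether a methoxy group or an amine on this aromatic carbon would also stay within the scatter of compound 2.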